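From 3-bromobenzyl to allyl: an expected loss of inhibition

The compounds below may be only part of what the source reports. "The series", "measured", "known", "first", "only" and "open" are said of these compounds alone.

In a functional assay on MCF7 cells (Homo sapiens) for inhibition, read by MTT assay, with a stated time of 72 h (on this read-out higher numbers stand for weaker inhibition and lower numbers for stronger inhibition), three compounds sharing one core have been read so far. Compound 1 (`Cc1cc(Nc2cc(-c3ccccc3)[nH]n2)n2nc(SCc3ccc(F)cc3)nc2n1`) gives 4020 nM as its value, and compound 3 (`Cc1cc(Nc2cc(-c3ccccc3)[nH]n2)n2nc(SCc3cccc(Br)c3)nc2n1`) gives 5140 nM as its value. Compound 2 (`Cc1cc(Nc2cc(-c3ccccc3)[nH]n2)n2nc(SCC3CCCCC3)nc2n1`) reads > 50000 nM here, and that is a limit of the assay, not a number. Only compound 1 and compound 3 give numbers, and the step between them (a 1.3-fold higher number from compound 1 to compound 3 (0.11 log units; within the scatter)) lies within the scatter.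

Compound 4 (`C=CCSc1nc2nc(C)cc(Nc3cc(-c4ccccc4)[nH]n3)n2n1`) comes next, and it differs from compound 3 as follows (vinyl in place of 3-bromophenyl on a saturated chain carbon bound to a sulfur): vinyl in place of 3-bromophenyl on a saturated chain carbon bound to a sulfur. For the measured compounds named here, no measured step makes this exact change. The nearest evidence is two steps at the same place, both resting on the limit of compound 2: cyclohexyl in place of 4-fluorophenyl (an at least 12-fold higher number from compound 1 to compound 2 (1.09 log units; beyond the scatter)) and 3-bromophenyl in place of cyclohexyl (an at least 9.7-fold lower number from compound 2 to compound 3 (0.98 log units; beyond the scatter)). Compound 4 carries no aromatic ring on that chain carbon, and neither does compound 2, so weaker inhibition is expected, though this rests on a single case. The expected change (a 3.9-fold higher number from compound 3 to compound 4 (0.59 log units; beyond the scatter)) lies beyond the scatter, toward a higher number. For compound 4 the estimated value is 20000 nM within a range from 7000 nM to 50000 nM on this read-out.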

Compound 4, half-maximal inhibitory concentration: > 50000 nM
Compound 4 gave a limit, no number; the forecaster's own chance of this, stated with the estimate: 30%; middle value at least 2.5-fold (0.39 log units) from the limit.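

With compound 4, a second group without an aromatic ring on the saturated chain carbon bound to a sulfur joins compound 2, and in this assay compound 4 gives > 50000 nM, which is a limit of the assay and not a number. The steps of an at least 9.7-fold higher number from compound 3 to compound 4 (0.98 log units; beyond the scatter) and an at least 12-fold higher number from compound 1 to compound 4 (1.09 log units; beyond the scatter) show that the earlier result with cyclohexyl was not a single case: vinyl, a group with no ring at all, also leaves the compound far from the values of the two aryl compounds, and among these four compounds only those carrying 3-bromophenyl or 4-fluorophenyl give numbers. The step between compound 2 and compound 4 cannot be read, because both stand at the same limit: the limit of > 50000 nM in this assay, at which 2 of the 4 values shown sit.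

The compounds shown leave open whether the aromatic ring alone is enough, which an unsubstituted phenyl or a pyridyl ring on that chain carbon would test. They also leave open whether a longer chain ending in a phenyl ring would give a number in this assay.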